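Same atoms, rejoined: a side-chain swap on an amide

A few compounds are considered here, and "the series" means these few. Any claim that something is new, unique, unknown or untested is made for them only; others in the source may bear on it.

In a functional assay on PC-3 cells (Homo sapiens) for antiproliferative activity, read by MTT assay, with a stated time of 24 h (a higher number here means a weaker inhibitor, a lower number a stronger inhibitor), compound 1 (`CCn1c(C(=O)NCCC(=O)OC)ccc1C(CC)(CC)c1ccc(OCS(=O)(=O)c2ccccc2)c(C)c1`) gives 40400 nM, compound 2 (`CCn1c(C(=O)NCCN)ccc1C(CC)(CC)c1ccc(OCS(=O)(=O)c2ccccc2)c(C)c1`) gives 6890 nM and compound 3 (`CCn1c(C(=O)N[C@@H](C)CO)ccc1C(CC)(CC)c1ccc(OCS(=O)(=O)c2ccccc2)c(C)c1`) gives 9520 nM. Compound 3 therefore stands level with compound 2, and well under compound 1, as a 4.2-fold lower number from compound 1 to compound 3 (0.63 log units; beyond the scatter) shows, much like a 5.9-fold lower number from compound 1 to compound 2 (0.77 log units; beyond the scatter). Compound 4 (`CCn1c(C(=O)NCCCO)ccc1C(CC)(CC)c1ccc(OCS(=O)(=O)c2ccccc2)c(C)c1`) rearranges compound 3: 3-hydroxypropyl in place of 1-(hydroxymethyl)ethyl on an amide-type nitrogen, with 3-hydroxypropyl in place of 1-(hydroxymethyl)ethyl on an amide-type nitrogen. Among the measured compounds shown here, no measured step makes this exact change. The closest guide is a 1.4-fold higher number from compound 2 to compound 3 (0.14 log units; within the scatter), another exchange on that nitrogen, so no shift beyond the scatter is expected. The expected step is a 1.1-fold lower number from compound 3 to compound 4 (0.02 log units; within the scatter). For compound 4 the estimate is 9000 nM, within an expected range of 4000 nM to 20000 nM.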

Compound 4, half-maximal inhibitory concentration: 11300 nM
Beside the measured number, compound 4's estimate is 1.3-fold (0.10 log units) below it, and the stated range covers the measured number.
By their numbers in this assay, from the lowest: compounds 2, 3 and 4 (each within the scatter of the next); then compound 1.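

Taking the hydroxyl further along the chain on the amide-type nitrogen, and losing the defined stereocentre of 1-(hydroxymethyl)ethyl, leaves the result in this assay within the scatter (with a 1.2-fold higher number from compound 3 to compound 4 (0.07 log units; within the scatter)). Hydroxymethyl in place of amino also stays within the scatter (with a 1.6-fold higher number from compound 2 to compound 4 (0.21 log units; within the scatter)), whereas hydroxymethyl in place of methoxycarbonyl does not (with a 3.6-fold lower number from compound 1 to compound 4 (0.55 log units; beyond the scatter)), so only the methoxycarbonyl chain stands apart among these four compounds. Nothing available here explains these results.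

Still open, as far as these compounds go, is how a carboxylic acid, a longer hydroxyalkyl chain or the mirror-image form of compound 3 would read.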